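Removing one trifluoromethyl from a urea-linked pyrazole series

This account rests on a few compounds, and the source may have more. Where it says the series, first, only, none or still open, it means among the compounds named here.

Of the compounds shown here, two of a shared core have been tested in a functional assay on HT-29 cells (Homo sapiens) for inhibition, read by sulforhodamine B assay, with a stated time of 48 h, tested at 100 uM; a lower number here means a stronger effect, a higher number a weaker effect of the compound at the concentration tested. Compound 1 `O=C(Nc1cccc(-n2cc(-c3ccncc3)c(-c3cc(O)cc(Cl)c3)n2)c1)Nc1ccc(Cl)c(Cl)c1` carries a dichlorophenyl urea and a hydroxyl on one aryl ring; in this assay compound 1 gives -70%. Compound 2 `COc1cc(Cl)cc(-c2nn(-c3cccc(NC(=O)Nc4cc(C(F)(F)F)cc(C(F)(F)F)c4)c3)cc2-c2ccncc2)c1` carries a methoxy in place of that hydroxyl and a urea bearing two trifluoromethyl groups; in this assay compound 2 gives -96%, the lowest of the two numbers, and its gap to compound 1 lies beyond the usual scatter. Compound 3 `COc1cc(Cl)cc(-c2nn(-c3cccc(NC(=O)Nc4cccc(C(F)(F)F)c4)c3)cc2-c2ccncc2)c1` differs from compound 2 in one place: hydrogen in place of trifluoromethyl on an aromatic carbon. Among the compounds with values here, no measured pair shows the effect of this single change, so the direction rests on the general picture that compound 2 is the strongest of the two. Compound 3 is expected to keep much of that effect, with a step of a number 18 percentage points higher from compound 2 to compound 3 (beyond the scatter) expected toward a weaker, higher number. The estimate for compound 3 in this assay is -78%, within -100% to -45%.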

Compound 3, a percentage reported as activity, at one concentration (the size of the read-out at that concentration, not a potency): -97%
The estimate for compound 3 lay 19 percentage points above the measured number, and the stated range covers the measured number.
By their numbers in this assay, from the lowest: compounds 3 and 2 (each within the scatter of the next); then compound 1.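

Hydrogen in place of trifluoromethyl on this aromatic carbon gives, in this assay, a number 1 percentage points lower from compound 2 to compound 3 (within the scatter), so this trifluoromethyl is not required to keep the read-out at the one concentration tested. Compounds 1 and 2 differ in more than one place and could not show this on their own; the pair of compound 2 and compound 3 isolates the position. This read-out is not a potency, and nothing at hand explains why the change leaves it in place.

As far as these compounds go, whether the remaining trifluoromethyl on the same ring can also give way to hydrogen stays open. So does the outcome with an amine or a carboxylic acid on this aromatic carbon, and whether a difference between compound 2 and compound 3 would appear at lower concentrations.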